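Nitro for amino in the aryl guanidine series

A few compounds are considered here, and "the series" means these few. Any claim that something is new, unique, unknown or untested is made for them only; others in the source may bear on it.

Of the compounds shown here, three have been measured in an assay on membranes from brain (Cavia porcellus) for binding affinity to Sigma non-opioid intracellular receptor 1 (Homo sapiens); on this read-out higher numbers stand for weaker inhibition and lower numbers for stronger inhibition. Compound 1 `Cc1ccccc1/N=C(/N)Nc1ccc([N+](=O)[O-])cc1C` gives 37 nM. Compound 3 `Cc1ccccc1/N=C(/N)Nc1ccc(N)cc1C` gives 280 nM. Compound 2 `Cc1ccccc1/N=C(/N)Nc1ccccc1N` gives 463 nM, and against compound 3 its number lies within the scatter, so the two are not separated; against compound 1 the gap is beyond the scatter.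

Compound 3 and compound 1 differ in one place, (nitro in place of amino on an aromatic carbon), and the step is a 7.6-fold lower number from compound 3 to compound 1 (0.88 log units; beyond the scatter). How the cores of compound 2 and compound 3 differ is not broken down here.

Compound 4 `Cc1ccccc1/N=C(/N)Nc1ccccc1[N+](=O)[O-]` is not yet measured. From compound 2 it differs by nitro in place of amino on an aromatic carbon. This is the same kind of change as from compound 3 to compound 1, not the same: there the place was meta to a methyl group and para to a large group, here it is ortho to a large group.

The expected step is a 5.1-fold lower number from compound 2 to compound 4 (0.71 log units; beyond the scatter), resting on compound 3 to compound 1 with a 7.6-fold lower number from compound 3 to compound 1 (0.88 log units; beyond the scatter). The place differs, so this expectation is taken with some caution. For compound 4 the estimate is 90 nM, between 30 nM and 300 nM.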

Compound 4, half-maximal inhibitory concentration: 113 nM
The estimate for compound 4 lay 1.3-fold (0.10 log units) below the measured number, within the range that was stated.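

In this assay, nitro in place of amino on an aromatic carbon gives a 4.1-fold lower number from compound 2 to compound 4 (0.61 log units; beyond the scatter), so the same direction of change appears on a second core, here at a place ortho to a large group. The sizes of the two steps cannot be separated: the same change on two cores in this assay, a 7.6-fold lower number (0.88 log units; beyond the scatter) from compound 3 to compound 1 and a 4.1-fold lower number (0.61 log units; beyond the scatter) from compound 2 to compound 4, 1.8-fold (0.27 log units) apart, within the scatter of two such steps

This supports carrying the change between these two cores as a working estimate, but two pairs do not establish a rule for the series, and core and place change together here, so the contribution of neither can be read alone.

Still open, from the compounds shown here alone, is whether the step belongs to nitro itself or would also appear with a nitrile, a methoxy group or a chlorine atom in place of the amino group. Also open, going by these compounds, is whether the step survives on a core carrying a longer chain in place of the methyl group.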